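Removing a nitro group from a weakly active macrocycle

The source may report more compounds than this note shows. Statements on the series, on what has been measured and on what is new or still open speak of the compounds shown alone.

The measure here is a functional assay on MCF7 cells (Homo sapiens) for antiproliferative activity, read by MTT assay, with a stated time of 72 h; on this read-out higher numbers stand for weaker inhibition and lower numbers for stronger inhibition. For the measured compounds named here, compound 1, `O=[N+]([O-])c1ccc(COc2ccc(Nc3ncnc4cc5c(cc34)OCCOCCO5)cc2)cc1`, is the only member of this small set with a number attached: in this assay compound 1 gives 39700 nM. Compound 2, `c1ccc(COc2ccccc2Nc2ncnc3cc4c(cc23)OCCOCCOCCOCCO4)cc1`, has no number, only a limit of the assay, > 100000 nM. Compound 3, `FC(F)(F)c1ccc(COc2ccccc2Nc2ncnc3cc4c(cc23)OCCOCCOCCO4)cc1`, likewise reaches only a limit, > 100000 nM. So compound 1 stands as the single measured value, and the limit of > 100000 nM in this assay, at which 2 of the 3 values shown sit, marks the ceiling against which the other two are reported. Because the limit of > 100000 nM in this assay, at which 2 of the 3 values shown sit, holds two of the three results, there is no measured step between any pair of these compounds to lean on.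

Compound 4, `c1ccc(COc2ccc(Nc3ncnc4cc5c(cc34)OCCOCCO5)cc2)cc1`, has not yet been tested. It differs from compound 1 in one place: hydrogen in place of nitro on an aromatic carbon. Compound 2 and compound 3 carry different rings and different substituents and cannot serve as a guide for this change. The expectation is therefore a step of a 1.5-fold higher number from compound 1 to compound 4 (0.18 log units; within the scatter), of a size not much beyond the usual scatter and leaning toward weaker inhibition. For compound 4 the estimated result is 60000 nM, expected to fall between 15000 nM and 200000 nM.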

Compound 4, half-maximal inhibitory concentration: > 100000 nM
Compound 4: a limit, no number (the forecaster's own chance of this, stated with the estimate: 35%); middle value at least 1.6-fold (0.22 log units) from the limit.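

In this assay compound 4 gives > 100000 nM, which is a limit of the assay and not a number. Going from 4-nitrobenzyl to benzyl, with nothing else altered, gives an at least 2.5-fold higher number from compound 1 to compound 4 (0.40 log units; beyond the scatter), so this one place on the aromatic ring does affect the read-out, and the weak activity of compound 1 is lost once the nitro group is gone. The full size of the step cannot be given, because compound 4 joins the other compounds at the ceiling of the assay: the limit of > 100000 nM in this assay, at which 3 of the 4 values shown sit.

On these data alone, with only nitro and hydrogen compared at this place, it remains open whether the nitro group is specifically required or whether another group there, such as an amine or a carboxylic acid, would keep or improve on the value of compound 1. Steps to compound 2 and compound 3 cannot be read, since both differ from compound 1 and compound 4 in more than one place and both stop at a limit, so nothing shows whether the nitro effect would carry over to their larger rings.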